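The source may report more compounds than this note shows. Statements on the series, on what has been measured and on what is new or still open speak of the compounds shown alone.

Measured compounds:
- compound 1, `O=C(NO)c1cccc(-c2cn([C@@H]3C[C@H](CO)N(CCCc4ccccc4)C3)nn2)c1`: < 10%
- compound 2, `O=C(NO)c1cccc(-c2cn([C@H]3C[C@H](CO)N(Cc4ccccc4)C3)nn2)c1`: < 10%
- compound 3, `O=C(NO)c1cccc(-c2cn([C@@H]3C[C@H](C(=O)O)N(Cc4ccccc4)C3)nn2)c1`: < 10%

These three compounds were examined in an assay on Sf9 cells for inhibition of histone deacetylase 11 (Homo sapiens), read by fluorescence, tested at 0.5 uM; on this read-out lower numbers stand for less inhibition and higher numbers for more inhibition at the one concentration tested (going by the name of the read-out). In this assay compound 1 gives < 10%, which is a limit of the assay and not a measured number. Compound 2 likewise gives < 10%, again a limit. Compound 3 gives < 10%, also a limit. Compound 3 therefore stands where every compound shown stands: at the limit, with no number to separate it from the other two, as the evidence records that (the limit of < 10% in this assay, at which 3 of the 3 values shown sit).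

The compound still to be measured is compound 4, `O=C(NO)c1cccc(-c2cn([C@@H]3C[C@H](CO)N(Cc4ccccc4)C3)nn2)c1`. It differs from compound 3 in one place: hydroxymethyl in place of carboxy on a saturated ring carbon. Carboxy leaves and hydroxymethyl enters, on the saturated ring carbon of the five-membered non-aromatic ring with one nitrogen.

Going by the values given here, no step between two measured compounds is available, so the size of the change from compound 3 to compound 4 in this assay cannot be read from a comparable pair. Given that every compound shown sits at the limit, the expectation is no step beyond the scatter, with compound 4 also expected to remain at or near the limit. The expected step is a step that the limit leaves unreadable from compound 3 to compound 4, and the estimated value for compound 4 is 5%, with a range from 0% to 15%.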

Compound 4, a percentage reported as inhibition, at one concentration (the size of the read-out at that concentration, not a potency): < 10%
Compound 4: only a limit was reported; the forecaster's own chance of this, stated with the estimate: 80%; the middle value does not contradict the limit.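

In this assay compound 4 gives < 10%, which is a limit and not a measured number. No size can be read for the steps to compound 4 from compound 1, compound 2 or compound 3: the limit of < 10% in this assay, at which 4 of the 4 values shown sit.

The compounds shown leave open whether swapping carboxy for hydroxymethyl, phenethyl for phenyl, or the configuration as drawn changes inhibition of this enzyme at all.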